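Urea aryl swap on the pyrazole series: dichlorophenyl for trifluoromethylphenyl

The source may report more compounds than this note shows. Statements on the series, on what has been measured and on what is new or still open speak of the compounds shown alone.

Measured compounds:
compound 1 `O=C(Nc1cccc(-n2cc(-c3ccncc3)c(-c3ccc(Cl)c(O)c3)n2)c1)Nc1cccc(C(F)(F)F)c1` gives > 32500 nM in a functional assay on HCC 2998 cells (Homo sapiens) for inhibition, read by sulforhodamine B assay, with a stated time of 48 h; on this read-out higher numbers stand for weaker inhibition of growth and lower numbers for stronger inhibition of growth
compound 2 `COc1cc(-c2nn(-c3cccc(NC(=O)Nc4cc(C(F)(F)F)cc(C(F)(F)F)c4)c3)cc2-c2ccncc2)ccc1Cl` gives 1870 nM in this assay

For compound 1 the result is only a limit of the assay, not a number (the limit of > 32500 nM in this assay, at which 1 of the 2 values shown sits). Among the compounds with values here, compound 2 differs from compound 1 in more than one place, so its value shows only that a measurable number is reached elsewhere. Compound 3 `O=C(Nc1cccc(-n2cc(-c3ccncc3)c(-c3ccc(Cl)c(O)c3)n2)c1)Nc1ccc(Cl)c(Cl)c1` carries 3,4-dichlorophenyl in place of 3-(trifluoromethyl)phenyl on an amide-type nitrogen, 3,4-dichlorophenyl in place of 3-(trifluoromethyl)phenyl on an amide-type nitrogen. Within the data shown here, no step between measured compounds exists for this change; in this assay no step beyond the scatter is expected, as an at least 1.0-fold lower number from compound 1 to compound 3 (0.03 log units; that floor lies within the scatter). Compound 3 is estimated at 30000 nM, between 8000 nM and 100000 nM, most likely again a limit.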

Compound 3, concentration for total growth inhibition: 13900 nM
Beside the measured number, compound 3's estimate is 2.2-fold (0.33 log units) above it; low and high end bracket the measured number.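

In this assay, within the data shown here, the first single change that can be read sits on an amide-type nitrogen: 3,4-dichlorophenyl in place of 3-(trifluoromethyl)phenyl gives an at least 2.3-fold lower number from compound 1 to compound 3 (0.36 log units; beyond the scatter). Compound 3 gives 13900 nM, a number rather than a limit, so on the core of compound 1 this one change is enough to reach a measurable value. The true size of the step stays unknown because its starting point is not a number: the limit of > 32500 nM in this assay, at which 1 of the 3 values shown sits.

Open, as far as these compounds go, is whether a single chlorine on the phenyl would give the same step. Also open, from the compounds shown here alone, is how an amine or a carboxylic acid on that ring would read in this assay.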